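The source may hold more compounds than are shown below. What is called first, only, known or untested is meant among the compounds shown, and "the series" means these compounds.

In a functional assay on MCF7 cells (Homo sapiens) for antiproliferative activity, read by MTT assay, with a stated time of 24 h (on this read-out higher numbers stand for weaker inhibition and lower numbers for stronger inhibition), compound 1 (`FC(F)(F)c1ccc(-c2nn(-c3ccccc3)cc2-c2nc3ccccc3[nH]2)cc1`) gives 6330 nM and compound 2 (`Cc1ccc(-c2nn(-c3ccccc3)cc2-c2nc3ccccc3n2S(=O)(=O)c2ccc(Cl)cc2)cc1`) gives 5930 nM. Compound 3 (`O=[N+]([O-])c1ccc(S(=O)(=O)n2c(-c3cn(-c4ccccc4)nc3-c3ccc(C(F)(F)F)cc3)nc3ccccc32)cc1`) reads 1130 nM, the lowest of the three numbers and beyond the scatter from both others. Compound 4 (`O=S(=O)(c1ccc(Cl)cc1)n1c(-c2cn(-c3ccccc3)nc2-c2ccc(C(F)(F)F)cc2)nc2ccccc21`) departs from compound 3 in one place, with chloro in place of nitro on an aromatic carbon, para to a large group: chloro in place of nitro on an aromatic carbon. Among the measured compounds shown here, no measured pair shows this exchange directly. The nearest evidence is a 5.6-fold lower number from compound 1 to compound 3 (0.75 log units; beyond the scatter), which accompanies (4-nitrophenyl)sulfonyl in place of hydrogen on an aromatic nitrogen, so it sizes the whole group and not its nitro alone. Compound 2 already carries the (4-chlorophenyl)sulfonyl group and stands at 5930 nM, but it also differs from compound 4 elsewhere, so it is only a loose guide. Part of the drop seen with compound 3 is therefore expected to be lost in this assay. The expected change is a 2.2-fold higher number from compound 3 to compound 4 (0.34 log units; beyond the scatter), a modest rise in the number. For compound 4 the estimated value is 2500 nM, with an expected range of 900 nM to 6500 nM.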

Compound 4, half-maximal inhibitory concentration: 4320 nM
Compound 4: middle estimate off by 1.7-fold (0.24 log units), on the low side; low and high end bracket the measured number.
By their numbers in this assay, from the lowest: compound 3; then compounds 4, 2 and 1 (each within the scatter of the next).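

Measured directly in this assay, chloro in place of nitro on this aromatic carbon, para to a large group, gives a 3.8-fold higher number from compound 3 to compound 4 (0.58 log units; beyond the scatter); among these compounds, the lower number of compound 3 therefore depends on the nitro and not on the sulfonyl link alone. With chloro in this place, the (4-chlorophenyl)sulfonyl group, taken as a whole, gives a 1.5-fold lower number from compound 1 to compound 4 (0.17 log units; within the scatter), and trifluoromethyl in place of methyl on an aromatic carbon gives a 1.4-fold lower number from compound 2 to compound 4 (0.14 log units; within the scatter), both within the scatter. No measurement here accounts for the difference between nitro and chloro.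

As far as these compounds go, whether an amine or a carboxylic acid at this position would read nearer to nitro or to chloro stays open. Also open, from the compounds shown here alone, is whether nitro would keep its step with methyl in place of trifluoromethyl.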